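The source may report more compounds than this note shows. Statements on the series, on what has been measured and on what is new or still open speak of the compounds shown alone.

Measured compounds:
- compound 1, `O=C1CCCC2=C1C(c1ccc(F)cc1)C=C(c1ccccc1)N2`: 21.9%
- compound 2, `CCOC(=O)C1=CC(c2ccc(Br)cc2)C2=C(CC(C)(C)CC2=O)N1`: "not active" (no number reported)
- compound 3, `CCOC(=O)C1(O)CC(c2ccccc2)C2=C(CC(C)(C)CC2=O)O1`: "not active" (no number reported)

In an assay on isolated protein for inhibition of glucose-6-phosphatase catalytic subunit 1 (Homo sapiens), read by inositol phosphate accumulation, with a stated time of 30 min, tested at 100 uM (on this read-out higher numbers stand for more inhibition at the one concentration tested (going by the name of the read-out) and lower numbers for less inhibition), compound 1 gives 21.9%. Compound 2 stands without a single number in this assay, recorded only as "not active" (no number reported), and compound 3 in the same way as "not active" (no number reported). Among the compounds with values here, no step between two measured compounds is available, so nothing can be said about how any single change moves the read-out within this set.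

Compound 4, `CCOC(=O)C1=CC(c2ccc(F)cc2)C2=C(CC(C)(C)CC2=O)N1`, is not yet measured in this assay. It differs from compound 2 by fluoro in place of bromo on an aromatic carbon, which, taken one bond further out, is the change from 4-bromophenyl to 4-fluorophenyl. Compound 1 also carries a 4-fluorophenyl group on a core that otherwise differs from that of compound 4 in the ester and in the two methyl groups, so it gives only a loose hint. Since compound 2 is recorded as "not active" (no number reported), the step to compound 4 in this assay is expected to stay small and to lie within the scatter, with at most a modest rise. Compound 4 is therefore estimated to give 10% in this assay, in the range 0% to 28%.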

Compound 4, a percentage reported as inhibition, at one concentration (the size of the read-out at that concentration, not a potency): "not active" (no number reported)
Nothing numeric was reported for compound 4, and the estimate cannot be compared.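

In this assay compound 2 stands as "not active" (no number reported) and compound 4 as "not active" (no number reported) and so no step can be read for the change from 4-bromophenyl to 4-fluorophenyl. No evidence bears on this result. The compounds shown leave open which differences between compound 1 and compound 4 go with the reading of compound 1.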